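Lengthening the Amide Chain in a Weak Inhibitor

The source may report more compounds than this note shows. Statements on the series, on what has been measured and on what is new or still open speak of the compounds shown alone.

Compound 1 `Brc1nn(-c2ccc3ncccc3c2)c2nc(Nc3cnn(C4CCNCC4)c3)ncc12` and compound 2 `COCCNC(=O)CNc1ncc2c(Br)nn(-c3ccc4ncccc4c3)c2n1` share the same core and differ only in the group attached to the nitrogen on the aromatic ring. In an assay on isolated protein for inhibition of eIF-2-alpha kinase GCN2 (Homo sapiens) (a higher number here means a weaker inhibitor, a lower number a stronger inhibitor), compound 1 gives 3 nM. Compound 2 in this assay gives > 1000 nM, which is a limit of the assay and not a number, so compound 2 stands at the weak end of the values shown, at the limit of > 1000 nM in this assay, at which 1 of the 2 values shown sits. Compound 3 `COCCNC(=O)CCNc1ncc2c(Br)nn(-c3ccc4ncccc4c3)c2n1` has not yet been measured in this assay. It differs from compound 2 by ((2-methoxyethyl)carbamoyl)methyl in place of (2-methoxyethyl)carbamoyl on a saturated chain carbon bound to a nitrogen on an aromatic ring; the same difference, cut one bond further out, reads ((2-methoxyethyl)carbamoyl)methyl to 2-((2-methoxyethyl)carbamoyl)ethyl. Within the data shown here, no step between two measured compounds that differ in one place is available, so the expected size of the step rests on compound 2 alone. Since compound 2 already sits at the limit with > 1000 nM, the expected step that the limit leaves unreadable from compound 2 to compound 3 is none beyond the scatter. Compound 3 is therefore estimated at 3000 nM in this assay, within a range from 800 nM to 20000 nM, and is most likely to be reported again only as a limit.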

Compound 3, half-maximal inhibitory concentration: > 1000 nM
Compound 3 ended at the assay's limit; the forecaster's own chance of this, stated with the estimate: 75%; the middle value is on the limit's open side.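

Compound 2 and compound 3 both give only a limit of the assay in this assay, not a number, so no step can be read between them: the limit of > 1000 nM in this assay, at which 2 of the 3 values shown sit.

The compounds shown leave open whether 2-((2-methoxyethyl)carbamoyl)ethyl and ((2-methoxyethyl)carbamoyl)methyl differ at all in their effect on inhibition, and how weak compound 2 and compound 3 really are.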